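Changing the Aryl Group on the Carbonyl Carbon

The compounds below may be only part of what the source reports. "The series", "measured", "known", "first", "only" and "open" are said of these compounds alone.

Compound 1 `CN(C)CCCOc1ccc(CN2CC[C@H](NC(=O)c3cc(Cl)cc(Cl)c3)C2)cc1`: 2000 nM
Compound 2 `Cc1ccc(C(=O)N[C@H]2CCN(Cc3ccc(OCCCN(C)C)cc3)C2)cc1C`: < 10000 nM, a limit of the assay
Compound 3 `Cc1cc(C(=O)N[C@H]2CCN(Cc3ccc(OCCCN(C)C)cc3)C2)ccc1Br`: 631 nM

In an assay on HEK293 cells for binding affinity to Urotensin-2 receptor (Homo sapiens), read by radioligand binding (a higher number here means a weaker inhibitor, a lower number a stronger inhibitor), compound 3 gives 631 nM, the lowest of the two numbers shown. Compound 1 gives 2000 nM, and the step of a 3.2-fold lower number from compound 1 to compound 3 (0.50 log units; beyond the scatter) is the only readable one. For compound 2 the assay reports only a limit, < 10000 nM. The steps a step that the limit leaves unreadable from compound 1 to compound 2 and a step that the limit leaves unreadable from compound 2 to compound 3 therefore cannot be sized.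

Compound 4 `CN(C)CCCOc1ccc(CN2CC[C@H](NC(=O)c3ccc(C(F)(F)F)cc3)C2)cc1` differs from compound 3 by 4-(trifluoromethyl)phenyl in place of 4-bromo-3-methylphenyl on a carbonyl carbon. Within the data shown here, no measured step contains this group; the one readable step shows that exchanging the aryl group on the carbonyl carbon shifts this assay modestly. The step of a 2.4-fold higher number from compound 3 to compound 4 (0.38 log units; beyond the scatter) is expected to be a modest rise. Compound 4 is estimated at 1500 nM, within 400 nM to 6000 nM.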

Compound 4, inhibition constant: < 10000 nM
Compound 4: a limit, no number; the forecaster's own chance of this, stated with the estimate: 20%; the middle value lies beyond the limit too.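

In this assay compound 4 gives only a limit, < 10000 nM, so its steps to compound 1, compound 2 and compound 3 cannot be read. From the compounds shown here alone, how compound 2 and compound 4 stand against compound 1, compound 3 and each other stays open: the limit of < 10000 nM in this assay, at which 2 of the 4 values shown sit.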